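The source may report more compounds than this note shows. Statements on the series, on what has been measured and on what is new or still open speak of the compounds shown alone.

In a functional assay on HCT-116 cells (Homo sapiens) for antiproliferative activity, read by MTT assay, with a stated time of 72 h (a higher number here means a weaker inhibitor, a lower number a stronger inhibitor), three compounds with a shared core differ only in the group on an amide-type nitrogen in a ring. Compound 1 `COc1ncc(-c2ccc3c(c2)N(c2ccc(C)cc2)C(=O)CO3)cc1NS(=O)(=O)c1ccc(F)cc1` gives 22700 nM. Compound 3 `COc1ccc(N2C(=O)COc3ccc(-c4cnc(OC)c(NS(=O)(=O)c5ccc(F)cc5)c4)cc32)cc1` gives 13400 nM, and the two are separated by a 1.7-fold lower number from compound 1 to compound 3 (0.23 log units; within the scatter). Compound 2 `COc1cccc(N2C(=O)COc3ccc(-c4cnc(OC)c(NS(=O)(=O)c5ccc(F)cc5)c4)cc32)c1` is reported only as a limit of the assay, > 40000 nM.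

Compound 4 `COc1ncc(-c2ccc3c(c2)N(C(C)C)C(=O)CO3)cc1NS(=O)(=O)c1ccc(F)cc1` carries isopropyl in place of 4-methoxyphenyl on that nitrogen: isopropyl in place of 4-methoxyphenyl on an amide-type nitrogen in a ring. The step that bears most directly on this site is an at least 2.9-fold lower number from compound 2 to compound 3 (0.47 log units; beyond the scatter), which shows that a change there can shift the number. Alongside it stands a 1.7-fold lower number from compound 1 to compound 3 (0.23 log units; within the scatter). Both steps keep an aromatic ring on the nitrogen, so neither gives a direction for its removal. No step beyond the scatter is therefore expected in this assay, although the uncertainty is wide. The expected change is a 1.1-fold higher number from compound 3 to compound 4 (0.05 log units; within the scatter). For compound 4 the estimated value is 15000 nM, with an expected range from 5000 nM to 40000 nM.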

Compound 4, half-maximal inhibitory concentration: 19200 nM
Estimate against measurement, compound 4: 1.3-fold (0.11 log units) below; low and high end bracket the measured number.
By their numbers in this assay, from the lowest: compounds 3, 4 and 1 (each within the scatter of the next). At a limit, above all of these: compound 2.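

In this assay, the aromatic ring on the amide-type nitrogen proves dispensable for the number: replacing it with isopropyl, a group with no ring, gives a 1.4-fold higher number from compound 3 to compound 4 (0.16 log units; within the scatter). Within the data shown here, the comparison with the 4-methylphenyl group reads the same, with a 1.2-fold lower number from compound 1 to compound 4 (0.07 log units; within the scatter), while the only step beyond the scatter is an at least 2.0-fold lower number from compound 2 to compound 4 (0.31 log units; beyond the scatter), so a ring on this nitrogen does not by itself set the number, and the position of the methoxy on it can matter. Compound 2 is reported only as a limit of the assay: the limit of > 40000 nM in this assay, at which 1 of the 4 values shown sits.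

The compounds shown leave open whether a methyl group, or a longer chain ending in an amine or a carboxylic acid, on this nitrogen would move the number beyond the scatter. They also leave open whether any group at this site can give a number far lower than these.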